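The compounds below may be only part of what the source reports. "The series", "measured", "known", "first", "only" and "open" are said of these compounds alone.

Compound 2 `Nc1ccc(Nc2nc(-c3cccc(F)c3)nc3ccc(F)cc23)cc1` is measured in a functional assay on MCF7 cells (Homo sapiens) for cytotoxicity, read by MTT assay, with a stated time of 48 h (on this read-out lower numbers stand for stronger inhibition and higher numbers for weaker inhibition), only to a limit: compound 2 gives > 50000 nM, a limit of the assay rather than a number. Compound 1 `Oc1cccc(Nc2nc(-c3cccc(F)c3)nc3ccc(F)cc23)c1` likewise reaches only a limit, giving > 50000 nM in this assay. The step that the two limits leave unreadable from compound 1 to compound 2 therefore cannot be read. Compound 3 `Nc1cccc(Nc2nc(-c3cccc(F)c3)nc3ccc(F)cc23)c1` differs from compound 2 by 3-aminophenyl in place of 4-aminophenyl on a nitrogen on an aromatic ring. Among the compounds with values here, both measured values sit at the same limit (the limit of > 50000 nM in this assay, at which 2 of the 2 values shown sit), so no measured step bears on this change. Compound 3 is therefore expected to give 50000 nM, with a range from 15000 nM to 150000 nM, most likely again as a limit. The expected step is a number no higher from compound 2 to compound 3 (the limit leaves the size open), within the scatter.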

Compound 3, half-maximal inhibitory concentration: > 50000 nM
Compound 3 gave a limit, no number; the forecaster's own chance of this, stated with the estimate: 75%; the middle value sits exactly at the limit.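

No step can be read among compound 1, compound 2 and compound 3, because all three values are limits of the assay, not numbers: the limit of > 50000 nM in this assay, at which 3 of the 3 values shown sit.

As far as these compounds go, whether 3-hydroxyphenyl, 4-aminophenyl and 3-aminophenyl differ at all on this read-out stays open.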